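The source may hold more compounds than are shown below. What is called first, only, known or untested is meant among the compounds shown, and "the series" means these compounds.

Compound 1, `N#Cc1ccc(Nc2nccc(Nc3ccc(-c4ccc(C#N)cc4)cc3F)n2)cc1`, gives 308000 nM.
Compound 2, `N#Cc1ccc(Nc2nccc(Oc3ccc(-c4ccc(C#N)cc4)c(F)c3)n2)cc1`, gives > 307000 nM.
Compound 3, `Cc1cc(C#N)ccc1-c1ccc(Oc2ccnc(Nc3ccc(C#N)cc3)n2)c(F)c1`, gives > 296000 nM.

These three values all come from a functional assay on MT4 cells (Homo sapiens) for cytotoxicity, read by MTT assay, with a stated time of 5 days; a higher number here means that more compound is tolerated, a lower number that less compound is tolerated. Compound 1 is the only one of the three with a definite number, 308000 nM. For compound 2 the result is a limit of this assay and not a number, > 307000 nM (the limit of > 307000 nM in this assay, at which 1 of the 3 values shown sits). Compound 3 likewise stands at a limit and not at a number, > 296000 nM (the limit of > 296000 nM in this assay, at which 1 of the 3 values shown sits), so its position among the three can only be said to be at or beyond the top of what this assay resolved, where the other two also sit.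

Compound 4, `N#Cc1ccc(Nc2nccc(Oc3ccc(-c4ccc(C#N)cc4)cc3F)n2)cc1`, has not yet been measured in this assay. It differs from compound 3 in one place: hydrogen in place of methyl on an aromatic carbon. Among the measured compounds shown here, no step between two measured compounds is available to gauge such a change. Given that all three measured values sit at or near the same high level, no step beyond the usual scatter is expected in either direction. Compound 4 is therefore expected to give about 300000 nM in this assay, within a range of 150000 nM to 600000 nM, which means an expected step that the limit leaves unreadable from compound 3 to compound 4, and it is expected that the assay may again report only a limit.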

Compound 4, half-maximal cytotoxic concentration: > 307000 nM
Compound 4: a limit, no number; the forecaster's own chance of this, stated with the estimate: 80%; middle value at least 1.0-fold (0.01 log units) from the limit.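

Compound 3 gives > 296000 nM, a limit of this assay. Compound 4 gives > 307000 nM, also a limit, so no step can be read between compound 3 and compound 4. The compounds shown leave open whether hydrogen in place of methyl on an aromatic carbon changes the tolerated concentration in this assay.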